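The source may report more compounds than this note shows. Statements on the series, on what has been measured and on what is new or still open speak of the compounds shown alone.

Measured in a functional assay on L1210 cells (Mus musculus) for inhibition; a lower number here means a stronger inhibitor, a higher number a weaker inhibitor:
compound 1 `C#CCN(Cc1ccc2nc(C)nc(O)c2c1)c1cccc(C(F)(F)F)c1` gives > 2200 nM
compound 2 `C#CCN(Cc1ccc2nc(C)nc(O)c2c1)c1ccc([N+](=O)[O-])cc1` gives 4700 nM
compound 3 `C#CCN(Cc1ccc2nc(C)nc(O)c2c1)c1ccc(C#N)c(C(F)(F)F)c1` gives > 2800 nM

Compound 3 stands at > 2800 nM, which is a limit and not a number. Compound 1 stands at > 2200 nM, which is also a limit. Compound 4 `C#CCN(Cc1ccc2nc(C)nc(O)c2c1)c1ccc([N+](=O)[O-])c(C(F)(F)F)c1` is compound 3 with nitro in place of cyano on an aromatic carbon, and the counted difference is nitro in place of cyano on an aromatic carbon.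

Among the compounds with values here, the one measured step is a step that the two limits leave unreadable from compound 1 to compound 3, which brings in the cyano and offers no size to carry forward. Within the data shown here, the only true number comes from compound 2, which carries nitro without the trifluoromethyl group and gives 4700 nM in this assay. On that value, compound 4 is expected to remain a weak inhibitor, with no change beyond the scatter expected in this assay and only a tentative direction. The estimated step is a step that the limit leaves unreadable from compound 3 to compound 4. For compound 4 the estimated value is 4500 nM, with an expected range of 1800 nM to 12000 nM.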

Compound 4, half-maximal inhibitory concentration: 5000 nM
Beside the measured number, compound 4's estimate is 1.1-fold (0.05 log units) below it; the measured number falls inside the stated range.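

In this assay, nitro para to a large group now has a readable step for the added trifluoromethyl group, a 1.1-fold higher number from compound 2 to compound 4 (0.03 log units; within the scatter), so compound 2 and compound 4 cannot be told apart and this pair shows no effect of that group on the read-out. Compound 4 also gives this position its first true number with trifluoromethyl present, but every step starting from compound 1 or compound 3 cannot be read, so nitro in place of cyano has no size. Compound 3 stands only as a limit: the limit of > 2800 nM in this assay, at which 1 of the 4 values shown sits.

Compound 1 likewise stands only as a limit: the limit of > 2200 nM in this assay, at which 1 of the 4 values shown sits.
From the compounds shown here alone, whether an amine or a carboxylic acid at this position, ortho to the trifluoromethyl group, would give a stronger inhibitor than compound 4 remains open.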